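Benzyloxy in place of dimethylamino on a shared core

The source may hold more compounds than are shown below. What is called first, only, known or untested is meant among the compounds shown, and "the series" means these compounds.

Compound 1, `CC(C)N(Cc1cccc(OCCCCCC(=O)O)c1)C(=O)c1ccc(-c2cccc(N(C)C)c2)cc1`, in an ADME assay on HEK293 cells (Homo sapiens) for cytotoxicity, read by CellTiter-Glo and resazurin assay, with a stated time of 72 h (a lower number here means that less compound is needed, a higher number that more compound is needed for the effect), gives > 26000 nM, which is a limit of this assay rather than a number.
Compound 2, `CC(C)N(Cc1cccc(OCCCCCC(=O)O)c1)C(=O)c1ccc(-c2cccc3ccccc23)cc1`, in this assay gives > 26000 nM, again a limit.
Compound 3, `CC(C)N(Cc1cccc(OCCCCCC(=O)O)c1)C(=O)c1ccc(-c2ccoc2)cc1`, in this assay gives > 26000 nM, also a limit.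

Compound 1 therefore stands only at a limit, and the two other values shown are limits as well. The steps a step that the two limits leave unreadable from compound 1 to compound 2, a step that the two limits leave unreadable from compound 1 to compound 3 and a step that the two limits leave unreadable from compound 2 to compound 3 cannot be sized because each of their end points is a limit; this is summed up by the limit of > 26000 nM in this assay, at which 3 of the 3 values shown sit.

The unmeasured compound 4 is `CC(C)N(Cc1cccc(OCCCCCC(=O)O)c1)C(=O)c1ccc(-c2cccc(OCc3ccccc3)c2)cc1`. It differs from compound 1 in one place: benzyloxy in place of dimethylamino on an aromatic carbon. The measured steps that bear on this change are those from compound 1, in which the group on the same aromatic carbon was exchanged for naphthalen-1-yl or furan-3-yl, and both left the value at the limit. Going by the values given here, no step here shows any size, so no direction can be read, and the expectation is that compound 4 also stays at the limit in this assay.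

Compound 4 is estimated at 30000 nM, with a range from 12000 nM to 80000 nM. This estimate means an expected step that the limit leaves unreadable from compound 1 to compound 4.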

Compound 4, half-maximal effective concentration: > 26000 nM
Compound 4 gave a limit, no number; the forecaster's own chance of this, stated with the estimate: 80%; the middle value is on the limit's open side.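

In this assay compound 4 gives > 26000 nM which is a limit and not a number. The step from compound 1 to compound 4 therefore cannot be read, and all the compounds end at the same point: the limit of > 26000 nM in this assay, at which 4 of the 4 values shown sit.

The compounds shown leave open whether any group at this place on the shared core would bring the effect to a readable concentration.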